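From 4-chlorophenyl to 3-bromophenyl: a step not yet measured

This account rests on a few compounds, and the source may have more. Where it says the series, first, only, none or still open, it means among the compounds named here.

In a functional assay on B16 cells (Mus musculus) for cytotoxicity, read by CCK-8 assay, with a stated time of 24 h (a higher number here means a weaker inhibitor, a lower number a stronger inhibitor), compound 1 `COc1ccccc1Oc1c(N)nc(-c2cccc(C)c2)nc1OCCO` gives 70900 nM, compound 2 `COc1ccccc1Oc1c(N)nc(-c2cccc(F)c2)nc1OCCO` gives 20900 nM, and compound 3 `COc1ccccc1Oc1c(N)nc(-c2ccc(Cl)cc2)nc1OCCO` gives 7740 nM, the lowest of the three numbers. Compound 4 `COc1ccccc1Oc1c(N)nc(-c2cccc(Br)c2)nc1OCCO` has 3-bromophenyl in place of 4-chlorophenyl on an aromatic carbon. Among the measured compounds shown here, no measured compound carries bromine, so the evidence is indirect. The closest guide is a 2.7-fold lower number from compound 2 to compound 3 (0.43 log units; beyond the scatter), a swap of 3-fluorophenyl for 4-chlorophenyl, while a 9.2-fold lower number from compound 1 to compound 3 (0.96 log units; beyond the scatter) marks the wider span and a 3.4-fold lower number from compound 1 to compound 2 (0.53 log units; beyond the scatter) shows that the group on the 3-substituted phenyl also moves the number. Partly reversing the swap suggests a small rise in this assay, so the expected step is a 1.8-fold higher number from compound 3 to compound 4 (0.26 log units; within the scatter). Compound 4 is estimated at 14000 nM, with an expected range of 5000 nM to 40000 nM.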

Compound 4, half-maximal inhibitory concentration: 21900 nM
Compound 4: middle estimate off by 1.6-fold (0.19 log units), on the low side; measured number inside the range.
By their numbers in this assay, from the lowest: compound 3; then compounds 2 and 4 (each within the scatter of the next); then compound 1.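

In this assay, the choice of group at the 3-position of the phenyl ring shows no clear difference between the two halogens, with a 1.0-fold higher number from compound 2 to compound 4 (0.02 log units; within the scatter) for bromo in place of fluoro. Bromo in place of methyl gives a 3.2-fold lower number from compound 1 to compound 4 (0.51 log units; beyond the scatter) and so lowers the number by a similar step to fluoro. The change to 3-bromophenyl gives a 2.8-fold higher number from compound 3 to compound 4 (0.45 log units; beyond the scatter) but alters both the halogen and where it sits, and no measurement here explains these differences.

Still open, on these data alone, is whether 3-chlorophenyl or 4-bromophenyl would separate the halogen from its position. As far as these compounds go, how an amine or a carboxylic acid on that phenyl ring would behave also remains unknown.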